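Notes on the step from compound 2 to compound 4

A few compounds are considered here, and "the series" means these few. Any claim that something is new, unique, unknown or untested is made for them only; others in the source may bear on it.

Measured in a functional assay on MCF7 cells (Homo sapiens) for inhibition, read by MTT assay (a lower number here means a stronger inhibitor, a higher number a weaker inhibitor), so far:
compound 1 `COc1cc2ncnc(Nc3ccc(NC(=O)c4ccc(C)cc4)cc3)c2cc1OC` gives 19000 nM
compound 2 `COc1cc2ncnc(Nc3ccc(NC(=O)c4cccc(F)c4)cc3)c2cc1OC` gives 13600 nM
compound 3 `COc1cc2ncnc(Nc3ccc(NC(=O)c4ccc(Br)cc4)cc3)c2cc1OC` gives 43000 nM

Among the compounds with values here, compound 2 at 13600 nM has no measured compound clearly under it. Two steps place it, a 1.4-fold lower number from compound 1 to compound 2 (0.15 log units; within the scatter) on one side and a 3.2-fold higher number from compound 2 to compound 3 (0.50 log units; beyond the scatter) on the other.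

Compound 4 `COc1cc2ncnc(Nc3ccc(NC(=O)c4ccccc4I)cc3)c2cc1OC` has 2-iodophenyl in place of 3-fluorophenyl on a carbonyl carbon. Within the data shown here, no measured compound carries 2-iodophenyl, so the guide is thin. The nearest measured exchange of the 3-fluorophenyl is the move to 4-bromophenyl in compound 3, the modest step of a 3.2-fold higher number from compound 2 to compound 3 (0.50 log units; beyond the scatter) above. The step of a 2.3-fold higher number from compound 1 to compound 3 (0.35 log units; beyond the scatter) also leads to compound 3 and points the same way.

On that basis a modest move to a higher number is expected in this assay for the new compound. The step expected is a 2.2-fold higher number from compound 2 to compound 4 (0.34 log units; beyond the scatter) on this reading. For compound 4 the estimated value is 30000 nM (expected range 10000 nM to 80000 nM).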

Compound 4, half-maximal inhibitory concentration: 37000 nM
For compound 4 the middle estimate is 1.2-fold (0.09 log units) below the measured one; the range from low to high includes it.
By their numbers in this assay, from the lowest: compounds 2, 1, 4 and 3 (each within the scatter of the next, the first and the last beyond it).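

In this assay, replacing 3-fluorophenyl with 2-iodophenyl on the carbonyl carbon gives a 2.7-fold higher number from compound 2 to compound 4 (0.43 log units; beyond the scatter). After the 4-bromophenyl of compound 3, this is a second exchange of the 3-fluorophenyl that ends beyond the scatter, although the halogen and its place on the ring both differ. The 2-iodophenyl cannot be separated from the other two groups, with a 1.2-fold lower number from compound 3 to compound 4 (0.07 log units; within the scatter) and a 1.9-fold higher number from compound 1 to compound 4 (0.29 log units; within the scatter), and nothing available explains these numbers.

Since the halogen and its place on the ring change together from compound 2 to compound 4, the share of each in the step remains unresolved. The compounds shown also leave open how this position responds to a phenyl ring carrying an amine or a carboxylic acid.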